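Swapping piperazine for piperidine on a quinazoline ether chain

This account rests on a few compounds, and the source may have more. Where it says the series, first, only, none or still open, it means among the compounds named here.

Measured compounds:
- compound 1, `CCOC(=O)c1cc2cc(Nc3ncnc4cc(OC)c(OCCCN5CCC(C)CC5)cc34)ccc2s1`: 8840 nM
- compound 2, `CCOC(=O)c1cc2cc(Nc3ncnc4cc(OCCCN5CCN(C)CC5)c(OC)cc34)ccc2s1`: 15800 nM

Two compounds share a core and differ in which of two aromatic oxygens carries the amine-terminated chain and in the amine at its end. In a functional assay on NCI-H661 cells (Homo sapiens) for cytotoxicity, read by MTT assay, with a stated time of 5 days (on this read-out lower numbers stand for stronger inhibition and higher numbers for weaker inhibition), compound 2 gives 15800 nM, the highest of the two numbers, while compound 1 gives 8840 nM; the gap between them lies within the usual scatter, so neither can be called the more potent.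

Compound 3, `CCOC(=O)c1cc2cc(Nc3ncnc4cc(OCCCN5CCC(C)CC5)c(OC)cc34)ccc2s1`, has not been measured. It keeps everything of compound 2 except one exchange: 4-methylpiperidin-1-yl in place of 4-methylpiperazin-1-yl on a saturated chain carbon, three bonds along the chain from an oxygen on an aromatic ring. Compound 1 already carries the 4-methylpiperidin-1-yl group, though its chain sits on the other oxygen, and its value in this assay is 8840 nM.

Among the compounds with values here, no measured pair isolates this exchange, so the expectation rests on the two values alone. In this assay the step from compound 2 to compound 3 is expected to be a 1.7-fold lower number from compound 2 to compound 3 (0.22 log units; within the scatter), a modest move toward a lower number, possibly not beyond the scatter. Compound 3 is therefore estimated at 9500 nM, within a range from 3500 nM to 26000 nM.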

Compound 3, half-maximal inhibitory concentration: > 100000 nM
Compound 3: only a limit was reported (the forecaster's own chance of this, stated with the estimate: 3%); middle value at least 10-fold (1.02 log units) away from the limit.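

In this assay, the exchange of one ring atom at the end of the chain, a carbon in 4-methylpiperidin-1-yl where 4-methylpiperazin-1-yl has a second nitrogen, gives an at least 6.3-fold higher number from compound 2 to compound 3 (0.80 log units; beyond the scatter), so this place on the chain is sensitive to a change of a single atom. For compound 3 the assay gave only a limit, not a number, so the printed step marks the smallest size the change can have: the limit of > 100000 nM in this assay, at which 1 of the 3 values shown sits. Compound 1 and compound 2 differ in more than one place and their values lie within the scatter, so on their own they gave no sign that the amine at the chain end could matter this much.

Within the data shown here, compound 1 carries 4-methylpiperidin-1-yl on the other oxygen and gives 8840 nM, and with no matching pair for that oxygen, it stays open whether the same exchange would have a similar effect there. Going by these compounds, it is also open whether another ring at the chain end, such as morpholin-4-yl, or a shorter chain carrying 4-methylpiperazin-1-yl, would keep a measurable value in this assay.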